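Swapping chloro for a chlorophenylamino group on compound 2

The compounds below may be only part of what the source reports. "The series", "measured", "known", "first", "only" and "open" are said of these compounds alone.

Measured compounds:
compound 1 `N#Cc1c(-c2ccc(Cl)cc2)nc(SCC(=O)Nn2c(COc3ccc(Cl)cc3Cl)nc3ccccc3c2=O)n(Cc2ccccc2)c1=O` with 72.7%
compound 2 `N#Cc1c(Cl)nc(SCC(=O)Nn2c(COc3ccc(Cl)cc3Cl)nc3ccccc3c2=O)nc1-c1ccc(O)cc1` with 72.7%
compound 3 `N#Cc1c(Nc2ccccc2)nc(SCC(=O)Nn2c(COc3ccc(Cl)cc3Cl)nc3ccccc3c2=O)nc1-c1ccc(Cl)cc1` with 43.6%

In a functional assay on the whole organism (strain albino) for inhibition, with Rattus norvegicus as the target, read by paw edema, with a stated time of 1 h, at a dose of 100 mg/kg by the oral route (on this read-out lower numbers stand for less inhibition and higher numbers for more inhibition at the one dose given (going by the name of the read-out)), compound 2 gives 72.7%, level with compound 1 at the digits shown, the two standing together as the highest of the three numbers. Compound 3 lies a long way lower at 43.6%, a gap well beyond the scatter; compound 3 carries a phenylamino group where compound 2 carries chloro, though the two differ elsewhere as well.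

Compound 4 is `N#Cc1c(Nc2ccc(Cl)cc2)nc(SCC(=O)Nn2c(COc3ccc(Cl)cc3Cl)nc3ccccc3c2=O)nc1-c1ccc(O)cc1`. It differs from compound 2 as follows: (4-chlorophenyl)amino in place of chloro on an aromatic carbon. The new group sits next to the ring nitrogen, ortho to the cyano group and meta to the 4-hydroxyphenyl group.

Going by the values given here, no single-change step between measured compounds exists to guide the size. Among the compounds with values here, still, an arylamino group at this place is seen only in compound 3, and a step downward is expected for compound 4 because compound 3 gives 43.6%. Compound 4 is therefore expected to reach 55%, between 40% and 70%, a step of a number 17.7 percentage points lower from compound 2 to compound 4 (beyond the scatter) that is estimated, not measured.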

Compound 4, a percentage reported as inhibition, in the whole organism at one dose (the size of the read-out at that dose, not a potency): 72.7%
For compound 4 the middle estimate is 17.7 percentage points below the measured one; the whole stated range lies below it.
By their numbers in this assay, from the lowest: compound 3; then compounds 1, 2 and 4 (each within the scatter of the next).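

In this assay, replacing chloro with (4-chlorophenyl)amino gives no change at the digits printed from compound 2 to compound 4 (within the scatter). This aromatic carbon, ortho to the cyano group, therefore accepts the added six-membered aromatic ring and hydrogen-bond donor with no readable shift in the number, and this single-change step shows that an arylamino group here does not by itself lower the read-out. Nothing available explains why the number holds across this change.

Compound 3 differs from compound 4 in more than one place, so its lower number cannot be assigned to any one of those differences. On these data alone, whether an amine such as methylamino or morpholine at this carbon would keep the number at the same level remains open, as does the role of the chlorine on the new phenyl ring.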